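Acetyl in place of the silicon-bearing group of compound 2

The compounds below may be only part of what the source reports. "The series", "measured", "known", "first", "only" and "open" are said of these compounds alone.

Compound 1 `C=C1CC[C@@H]2[C@](C)(CO[Si](C)(C)C(C)(C)C)[C@H](O)CC[C@@]2(C)[C@@H]1C/C=C1/C(=O)OC[C@H]1O` and compound 2 `C=C1CC[C@@H]2[C@](C)(CO[Si](C(C)C)(C(C)C)C(C)C)[C@H](O)CC[C@@]2(C)[C@@H]1C/C=C1/C(=O)OC[C@H]1O` share one core and differ only in the silicon-bearing group on an oxygen on a saturated carbon. In a functional assay on ASK cells (Rattus norvegicus) for cytotoxicity, read by sulforhodamine B assay (a higher number here means that more compound is needed for the effect, a lower number that less compound is needed), compound 1 gives 15.5 uM and compound 2 gives 2.85 uM, so compound 2 holds the lower of the two numbers.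

Compound 3 `C=C1CC[C@@H]2[C@](C)(COC(C)=O)[C@H](O)CC[C@@]2(C)[C@@H]1C/C=C1/C(=O)OC[C@H]1O` keeps the same core and carries acetyl at that place: a group of 3 heavy atoms (2 carbon, 1 oxygen; no ring) in place of a group of 10 heavy atoms (9 carbon, 1 silicon; no ring), on an oxygen on a saturated carbon. Going by the values given here, the one measured step that bears on this change is a 5.4-fold lower number from compound 1 to compound 2 (0.74 log units; beyond the scatter). It is modest but beyond the scatter, and there the group with more heavy atoms went with the lower number. Acetyl has fewer heavy atoms than either silicon-bearing group and contains no silicon. Among the compounds with values here, no measured compound carries it, so this single step is only a loose guide. A move of similar size toward a higher number in this assay is expected, with wide uncertainty. The estimated step is a 6.3-fold higher number from compound 2 to compound 3 (0.80 log units; beyond the scatter). Compound 3 is expected at about 18 uM, within an estimated range of 6 uM to 50 uM.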

Compound 3, concentration for half-maximal effect: 16.7 uM
Compound 3: middle estimate off by 1.1-fold (0.03 log units), on the high side; the range from low to high includes it.
By their numbers in this assay, from the lowest: compound 2; then compounds 1 and 3 (each within the scatter of the next).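

Working notes: in this assay, acetyl and the group of 7 heavy atoms read alike on this oxygen, with a 1.1-fold higher number from compound 1 to compound 3 (0.03 log units; within the scatter), so the presence of silicon does not by itself separate compound 1 from compound 3. Compound 2 now stands apart from both neighbours, with a 5.9-fold higher number from compound 2 to compound 3 (0.77 log units; beyond the scatter), which ties its lower number to the group of 10 heavy atoms specifically and shows that the number does not follow heavy-atom count evenly across these three compounds, since only the largest group departs from the other two. The data at hand offer nothing that accounts for this behaviour at the position.

Still open, on these data alone, is whether the lower number needs silicon at all, or whether an all-carbon group of similar size, such as a benzyl ether or a longer acyl chain like pivaloyl, would read like compound 2. Also open, as far as these compounds go, is how the free hydroxyl or an amine-bearing chain at this oxygen would compare with acetyl, and whether a silicon group larger than that of compound 2 would extend the step or reverse it.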